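This account rests on a few compounds, and the source may have more. Where it says the series, first, only, none or still open, it means among the compounds named here.

In a functional assay on MCF7 cells (Homo sapiens) for inhibition, in the absence of a further agent (on this read-out lower numbers stand for stronger inhibition and higher numbers for weaker inhibition), compound 1 (`Nc1ccc(-c2cc(=O)c3c(N)c(Br)cc(Br)c3o2)cc1`) gives 6300 nM. Compound 2 (`Nc1ccc(-c2cc(=O)c3c(N)c(Cl)cc(Cl)c3o2)cc1`) gives 53 nM, with two chloro groups where compound 1 has two bromo groups. Compound 2 holds the lower of the two numbers, and the gap between them lies well beyond the usual scatter of repeat measurements.

Compound 3 (`Nc1ccc(-c2cc(=O)c3c(N)c(Cl)ccc3o2)cc1`) comes from compound 2 by a single change: hydrogen in place of chloro on an aromatic carbon. Hydrogen takes the place of chloro on an aromatic carbon, para to an amino group and meta to the remaining chloro group.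

Within the data shown here, no measured pair here differs in one place only, so the data give no direct guide to the size of this step. The two measured values show that the number can move a long way between two compounds that differ in both halogen groups, so the range has to stay wide. The likeliest outcome is no step beyond the scatter, with a slight lean toward a lower number. The estimated step is a 1.3-fold lower number from compound 2 to compound 3 (0.12 log units; within the scatter). For compound 3 the expected value is 40 nM, with an estimated range of 8 nM to 250 nM.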

Compound 3, half-maximal inhibitory concentration: 3.9 nM
Beside the measured number, compound 3's estimate is 10-fold (1.01 log units) above it; measured number outside the range, below it.
By their numbers in this assay, from the lowest: compound 3; then compound 2; then compound 1.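

In this assay the swap of the chloro group for hydrogen, on the aromatic carbon para to an amino group, gives a 14-fold lower number from compound 2 to compound 3 (1.13 log units; beyond the scatter) and so shows that this position matters a great deal to the read-out, with the chloro group there going along with weaker inhibition. This is the first comparison among these compounds that changes one place only, whereas the earlier pair differed in both halogen groups at once, so the size of the step can now be tied to this single carbon. The change removes just one heavy atom and no hydrogen-bond donor or acceptor, yet the number still moves far beyond the scatter, and nothing measured here speaks to why it falls.

On these data alone, whether hydrogen is the best choice at this carbon, or whether a fluoro, methyl or methoxy group would give a similar number, stays open. Equally open is what the remaining chloro group contributes to the value of compound 3, and the compounds shown offer no step that changes that group alone.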